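The source may hold more compounds than are shown below. What is called first, only, known or untested is meant among the compounds shown, and "the series" means these compounds.

The measured compounds:
Compound 1 `ClCc1ccccc1Cn1cnc2c(Cl)ncnc21` in a functional assay on TK-10 cells (Homo sapiens) for cytotoxicity, read by sulforhodamine B assay, with a stated time of 48 h (a higher number here means that more compound is tolerated, a lower number that less compound is tolerated), gives 95500 nM.
Compound 2 `ClCc1cccc(Cn2cnc3ncnc(Cl)c32)c1` in this assay gives 6300 nM.
Compound 3 `ClCc1ccccc1Cn1cnc2ncnc(Cl)c21` in this assay gives 33900 nM.

Among these three numbers compound 3 holds the second highest. Compound 1 stands nearest to it with a higher number, compound 2 furthest with a lower one, and both gaps lie beyond the usual scatter. Compound 4 `ClCc1ccccc1Cn1cnc2nc(Cl)nc(Cl)c21` differs from compound 3 by one change: chloro in place of hydrogen on an aromatic carbon. Among the measured compounds shown here, no measured pair shows this change, so its effect is not known from these data. In this assay compound 4 is expected to show only a small step, a lower number being somewhat more likely than a higher one, and possibly none beyond the scatter. The expected step is a 1.4-fold lower number from compound 3 to compound 4 (0.13 log units; within the scatter). Compound 4 is thus estimated at 25000 nM, in a range from 8000 nM to 80000 nM.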

Compound 4, concentration lethal to 50% of the cells: 60300 nM
Estimate against measurement, compound 4: 2.4-fold (0.38 log units) below; measured number inside the range.
By their numbers in this assay, from the lowest: compound 2; then compounds 3, 4 and 1 (each within the scatter of the next, the first and the last beyond it).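

Chloro in place of hydrogen gives a 1.8-fold higher number from compound 3 to compound 4 (0.25 log units; within the scatter) in this assay when it sits on the aromatic carbon between two ring nitrogen atoms. Among the compounds shown here, this is the first reading of this change here, and it shows that this position takes a chloro group with no step beyond the scatter. Nothing on hand explains the result.

On these data alone, whether an amine or a methoxy group at this position would give a step beyond the scatter stays open. So does whether the same chloro change would read alike on compound 2.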